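Swapping the saturated ring on a shared core

The source may hold more compounds than are shown below. What is called first, only, known or untested is meant among the compounds shown, and "the series" means these compounds.

Measured compounds:
compound 1, `CCC1(O)CCN(c2nc(C)c3cc(NC(=O)COc4ccc(OC(F)(F)F)cc4)ccc3n2)CC1`: 116 nM
compound 2, `Cc1nc(N2CCC(O)CC2)nc2ccc(NC(=O)COc3ccc(Cl)cc3)cc12`: 150 nM

Of the compounds shown here, two on a shared core have been tested in an assay on CHO-K1 cells for displacement of a labelled ligand from melanin-concentrating hormone receptor 1 (Homo sapiens), with a stated time of 2 h; on this read-out lower numbers stand for stronger inhibition and higher numbers for weaker inhibition. In this assay compound 1 gives 116 nM, and compound 2 gives 150 nM. These two numbers lie within the usual scatter of each other, so neither compound can be set apart from the other on this read-out. Among the compounds with values here, no step between them is worked out, as they differ in more than one place.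

The new compound is compound 3, `Cc1nc(N2CCN(C(=O)C3CC3)CC2)nc2ccc(NC(=O)COc3ccc(OC(F)(F)F)cc3)cc12`. It differs from compound 1 in one place: 4-(cyclopropylcarbonyl)piperazin-1-yl in place of 4-ethyl-4-hydroxypiperidin-1-yl on an aromatic carbon. The group that leaves carries one hydrogen-bond donor; the group that enters carries none, and it brings a three-membered ring and a carbonyl. Within the data shown here, with only two measured values and no single-change step to lean on, nothing in the data marks this change as helpful or harmful. A step near the edge of the scatter, toward a somewhat higher number, is expected: a 1.9-fold higher number from compound 1 to compound 3 (0.28 log units; within the scatter). Compound 3 is therefore estimated at 220 nM, with a range from 60 nM to 800 nM.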

Compound 3, half-maximal inhibitory concentration: 49 nM
Beside the measured number, compound 3's estimate is 4.5-fold (0.65 log units) above it, and the stated range ends above it.
By their numbers in this assay, from the lowest: compound 3; then compounds 1 and 2 (each within the scatter of the next).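

In this assay, within the data shown here, the group on the aromatic carbon between two ring nitrogen atoms proves able to shift the read-out: 4-(cyclopropylcarbonyl)piperazin-1-yl in place of 4-ethyl-4-hydroxypiperidin-1-yl gives a 2.4-fold lower number from compound 1 to compound 3 (0.37 log units; beyond the scatter), a modest step, but the first single-place change here that lies beyond the scatter. The hydrogen-bond donor of the group that leaves is also not required for a number this low, since the group that enters carries none, although this swap alters the ring, adds a three-membered ring and brings in a carbonyl all at once, so the step cannot be credited to any one of these features. No measurement available here explains the step.

On these data alone, it remains open whether the three-membered ring matters or whether the carbonyl on the piperazine is enough, a question that a plain acetyl group or a longer chain ending in a carbonyl could help to settle. As far as these compounds go, it is also open how a free amine on the piperazine, with no carbonyl at all, would compare with compound 3.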